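Removing the methoxy group from compound 3

A few compounds are considered here, and "the series" means these few. Any claim that something is new, unique, unknown or untested is made for them only; others in the source may bear on it.

Measured in a functional assay on P388 cells (Mus musculus) for cytotoxicity, read by MTT assay, with a stated time of 72 h; on this read-out higher numbers stand for weaker inhibition and lower numbers for stronger inhibition:
compound 1 `Cc1c(/N=C/c2ccc(N(C)C)cc2)c(=O)n(-c2ccccc2)n1C`, 468000000 nM;
compound 2 `Cc1c(/N=C/c2cccc(O)c2)c(=O)n(-c2ccccc2)n1C`, 437000000 nM;
compound 3 `COc1ccccc1/C=N/c1c(C)n(C)n(-c2ccccc2)c1=O`, 229000000 nM.

Compound 3 stands at 229000000 nM in this assay. Against compound 2 the step is small: a 1.9-fold lower number from compound 2 to compound 3 (0.28 log units; within the scatter). Compound 1, at 468000000 nM, lies beyond the scatter from compound 3, and this is the only gap among the three that does.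

Compound 4 `Cc1c(/N=C/c2ccccc2)c(=O)n(-c2ccccc2)n1C` has not yet been measured. It differs from compound 3 by hydrogen in place of methoxy on an aromatic carbon. For the measured compounds named here, the one measured step that bears on a change at this part of the molecule, from compound 2 to compound 3, swapped one substituted phenyl for another and stayed within the scatter. The three measured compounds as a whole spread over a narrow band, none far from the others. On that basis no step beyond the scatter is expected in this assay from compound 3 to compound 4, and the expected step is a 1.3-fold higher number from compound 3 to compound 4 (0.12 log units; within the scatter). Compound 4 is estimated at 300000000 nM, within a range from 150000000 nM to 600000000 nM.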

Compound 4, half-maximal inhibitory concentration: 240000000 nM
The estimate for compound 4 lay 1.3-fold (0.10 log units) above the measured number; low and high end bracket the measured number.
By their numbers in this assay, from the lowest: compounds 3, 4, 2 and 1 (each within the scatter of the next, the first and the last beyond it).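

With compound 4 the unsubstituted phenyl gives a reference against which each substituent can be read in this assay. Taking away the methoxy group, ortho to a large group, leaves the number within the scatter (a 1.0-fold higher number from compound 3 to compound 4 (0.02 log units; within the scatter)), and the hydroxy and dimethylamino groups, each read against hydrogen, do not move it beyond the scatter either (a 1.8-fold lower number from compound 2 to compound 4 (0.26 log units; within the scatter); a 2.0-fold lower number from compound 1 to compound 4 (0.29 log units; within the scatter)). Nothing available bears on why these substituents make so little difference.

As far as these compounds go, whether a carboxylic acid, a nitro group or a longer chain on this phenyl would shift the number beyond the scatter stays open. So does whether replacing the phenyl on the other side of the shared core, or the imine link itself, would matter more than these substituents do.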